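Pyridin-2-yl in place of phenyl on a ring amine nitrogen

The source may report more compounds than this note shows. Statements on the series, on what has been measured and on what is new or still open speak of the compounds shown alone.

Measured compounds:
compound 1 `CC(C)CCn1ccc(N2CCc3ccccc3C2)c(C#N)c1=O`: 871 nM
compound 2 `CC(C)CCn1ccc(N2CCN(c3ccccc3)CC2)c(C#N)c1=O`: 661 nM

Of the compounds shown here, two built on a shared core have been measured. In a functional assay on CHO cells for positive allosteric modulation of metabotropic glutamate receptor 2 (Homo sapiens), with a stated time of 30 min (on this read-out higher numbers stand for an effect only at larger amounts of compound and lower numbers for an effect already at smaller amounts), compound 1 gives 871 nM, and compound 2 gives 661 nM. Among the measured compounds shown here, compound 2 is one of only two measured compounds; its number and that of compound 1 lie within the scatter of each other, so neither stands apart and no order between them can be read.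

Compound 3 `CC(C)CCn1ccc(N2CCN(c3ccccn3)CC2)c(C#N)c1=O` differs from compound 2 in one place: pyridin-2-yl in place of phenyl on an amine nitrogen in a ring. For the measured compounds named here, no measured pair traces this change, so the data give neither its size nor its direction. The step from compound 2 to compound 3 is therefore expected to stay within the scatter, with no movement beyond it. For compound 3 the half-maximal effective concentration is estimated at 700 nM, with a range from 250 nM to 2000 nM. This estimate means a step of a 1.1-fold higher number from compound 2 to compound 3 (0.02 log units; within the scatter) that is expected to be small.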

Compound 3, half-maximal effective concentration: 3090 nM
Compound 3: the middle estimate sits 4.4-fold (0.64 log units) below what was measured, and the stated range ends below it.
By their numbers in this assay, from the lowest: compounds 2 and 1 (each within the scatter of the next); then compound 3.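

In this assay, among the compounds shown here, the group on the ring amine nitrogen proves sensitive to a small edit: pyridin-2-yl in place of phenyl brings a 4.7-fold higher number from compound 2 to compound 3 (0.67 log units; beyond the scatter) and so moves the number beyond the scatter, which compounds 1 and 2, with no step between them, could not show. Both groups are six-membered aromatic rings, yet the one with a hetero atom and a hydrogen-bond acceptor needs larger amounts of compound for the effect, so this position does not accept every such ring alike. No measurement here bears on why the number rises.

Going by these compounds, whether pyridin-3-yl or pyridin-4-yl on the same nitrogen would follow pyridin-2-yl remains open. So does the effect of a fluorine or a methoxy group on the phenyl ring.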